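A few compounds are considered here, and "the series" means these few. Any claim that something is new, unique, unknown or untested is made for them only; others in the source may bear on it.

Compound 2 `COc1ccc(N2CCN(Cn3nc(-c4ccc5c(c4)OCCO5)oc3=S)CC2)cc1` is one of three close relatives tested in a functional assay on HepG2 cells (Homo sapiens) for antiproliferative activity, read by MTT assay, with a stated time of 48 h; a lower number here means a stronger inhibitor, a higher number a weaker inhibitor. In this assay compound 2 gives only a limit of the assay, > 50000 nM. Compound 1 `S=c1oc(-c2ccc3c(c2)OCCO3)nn1CN1CCN(c2ccc(Cl)cc2)CC1` carries a chloro group where compound 2 carries methoxy. In this assay compound 1 likewise gives a limit, > 50000 nM. Compound 3 `Fc1ccc(N2CCN(Cn3nc(-c4ccc5c(c4)OCCO5)oc3=S)CC2)cc1` carries fluoro in that place. In this assay compound 3 also gives a limit, > 50000 nM. Because all three sit at the limit of > 50000 nM in this assay, at which 3 of the 3 values shown sit, none of the steps among them can be sized: a step that the two limits leave unreadable from compound 1 to compound 2, a step that the two limits leave unreadable from compound 1 to compound 3 and a step that the two limits leave unreadable from compound 2 to compound 3. Compound 4 `COc1cccc(N2CCN(Cn3nc(-c4ccc5c(c4)OCCO5)oc3=S)CC2)c1` differs from compound 2 by 3-methoxyphenyl in place of 4-methoxyphenyl on an amine nitrogen in a ring. Among the compounds with values here, no measured step speaks directly to this rearrangement, and the three unreadable steps give no direction to expect in this assay. Compound 4 is therefore expected to return a limit as well, with an estimate of 50000 nM and a range from 20000 nM to 100000 nM. The estimated step of a number no higher from compound 2 to compound 4 (the limit leaves the size open) is expected to be none beyond the scatter.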

Compound 4, half-maximal inhibitory concentration: 21400 nM
Estimate against measurement, compound 4: 2.3-fold (0.37 log units) above; the range from low to high includes it.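

Within the data shown here, replacing 4-methoxyphenyl with 3-methoxyphenyl on the amine nitrogen in a ring gives the first readable step in this assay: an at least 2.3-fold lower number from compound 2 to compound 4 (0.36 log units; beyond the scatter). Set against the chloro and fluoro relatives, the 3-methoxyphenyl group gives an at least 2.3-fold lower number from compound 1 to compound 4 (0.36 log units; beyond the scatter) and an at least 2.3-fold lower number from compound 3 to compound 4 (0.36 log units; beyond the scatter), whereas the steps among those three earlier compounds cannot be read. So where the methoxy group sits on this aromatic ring changes the result by more than the scatter, but each step has only a lower bound, because the other three compounds remain at a limit of the assay: the limit of > 50000 nM in this assay, at which 3 of the 4 values shown sit.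

The compounds shown leave open how far the true size of these steps extends. They also leave open whether an ethoxy group, a hydroxyl or an amine in the place of this methoxy group would give a readable value.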